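The source may hold more compounds than are shown below. What is called first, only, known or untested is meant among the compounds shown, and "the series" means these compounds.

In an ADME assay on microsomes from liver (Mus musculus) for metabolic stability, read by LC-MS, with a stated time of 30 min, tested at 1 uM (on this read-out lower numbers stand for a less stable compound and higher numbers for a more stable compound), compound 1 `O=C(NCc1ccc(S(=O)(=O)N2CCCCC2)cc1)c1cc2cnccc2s1` gives "below limit of detection" (no number reported). Compound 2 `O=C(NCc1ccc(S(=O)(=O)N2CCCCC2)cc1)c1cc2cnccc2o1` gives 4.6%. For the measured compounds named here, compound 3 `O=C(NCc1ccc(S(=O)(=O)N2CCCCC2)cc1)c1cnc2nccn2c1` gives 0.28%, within the scatter of compound 2, the only other number. Compound 4 `O=C(NCc1ccc(S(=O)(=O)c2cc(F)cc(F)c2)cc1)c1cnc2nccn2c1` carries 3,5-difluorophenyl in place of piperidin-1-yl on a sulfonyl sulfur. Going by the values given here, the sole measured step, a number 4.3 percentage points lower from compound 2 to compound 3 (within the scatter), changes the group on the carbonyl carbon, not this place, and stays within the scatter. Among the compounds with values here, no measured step touches the sulfonyl sulfur, so the expectation in this assay is weak, and no step beyond the scatter is expected. The estimated change is a number 3.7 percentage points higher from compound 3 to compound 4 (within the scatter). For compound 4 the estimated value is 4%, with an expected range of 0.3% to 20%.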

Compound 4, percent of the compound remaining: 71%
Compound 4: middle estimate off by 67 percentage points, on the low side, and the stated range ends below it.
By their numbers in this assay, from the lowest: compounds 3 and 2 (each within the scatter of the next); then compound 4.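

In this assay the group on the sulfonyl sulfur proves able to move the read-out: 3,5-difluorophenyl in place of piperidin-1-yl gives a number 70.7 percentage points higher from compound 3 to compound 4 (beyond the scatter) and lifts the series clear of the scatter, which the change on the carbonyl carbon between compound 2 and compound 3 did not do. Nothing available accounts for the size of this step. From the compounds shown here alone, whether the ring alone or its two fluorine atoms carry the step remains open, as a plain phenyl group would separate the two. Also open, going by these compounds, is whether the step holds with the carbonyl-carbon group of compound 2.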